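Tetrazole for Nitrile on the Benzenesulfonyl Arm

The source may hold more compounds than are shown below. What is called first, only, known or untested is meant among the compounds shown, and "the series" means these compounds.

Measured compounds:
compound 1 `O=C(O)c1cccc(S(=O)(=O)N2CCC(NS(=O)(=O)c3cc(S(=O)(=O)c4ccccc4)ccc3C(F)(F)F)CC2)c1` gives 190 nM
compound 2 `O=C(O)c1ccc(S(=O)(=O)N2CCC(NS(=O)(=O)c3cc(S(=O)(=O)c4ccccc4)ccc3C(F)(F)F)CC2)cc1` gives 110 nM
compound 3 `N#Cc1cccc(S(=O)(=O)N2CCC(NS(=O)(=O)c3cc(S(=O)(=O)c4ccccc4)ccc3C(F)(F)F)CC2)c1` gives 170 nM

All three were measured in an assay on U2OS cells for inhibition of secreted frizzled-related protein 1 (Homo sapiens), read by a luciferase reporter, with a stated time of 18 h; on this read-out lower numbers stand for an effect already at smaller amounts and higher numbers for an effect only at larger amounts of compound. Compound 3 stands second highest of the three numbers, with compound 1 nearest and compound 2 furthest, and both of those gaps lie within the scatter, so no order among them can be claimed.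

Compound 4 `O=S(=O)(NC1CCN(S(=O)(=O)c2cccc(-c3nnn[nH]3)c2)CC1)c1cc(S(=O)(=O)c2ccccc2)ccc1C(F)(F)F` differs from compound 3 in one place: 1H-tetrazol-5-yl in place of cyano on an aromatic carbon. Going by the values given here, the only measured step that bears on a change at this site is a 1.1-fold lower number from compound 1 to compound 3 (0.05 log units; within the scatter), in which carboxy gave way to cyano on the same aromatic carbon and the number did not move beyond the scatter. The step of a 1.7-fold lower number from compound 1 to compound 2 (0.24 log units; within the scatter), moving the carboxy to the 4-position, was likewise within the scatter. Nothing here suggests that a swap of a small group at this position shifts the read-out.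

Compound 4 is therefore expected to sit close to compound 3, with a 1.1-fold lower number from compound 3 to compound 4 (0.05 log units; within the scatter) amounting to no step beyond the scatter. The estimated value of compound 4 in this assay is 150 nM, within a range of 60 nM to 400 nM.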

Compound 4, half-maximal effective concentration: 1200 nM
Compound 4: middle estimate off by 8.0-fold (0.90 log units), on the low side; the whole stated range lies below it.
By their numbers in this assay, from the lowest: compounds 2, 3 and 1 (each within the scatter of the next); then compound 4.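

In this assay the aromatic carbon on this arm turns out not to treat every group alike: 1H-tetrazol-5-yl in place of cyano gives a 7.1-fold higher number from compound 3 to compound 4 (0.85 log units; beyond the scatter) and, in place of carboxy on the same carbon, a 6.3-fold higher number from compound 1 to compound 4 (0.80 log units; beyond the scatter) as well. Going by these compounds alone, the one earlier swap at this carbon, a 1.1-fold lower number from compound 1 to compound 3 (0.05 log units; within the scatter), had stayed within the scatter, so the flat picture it suggested holds for carboxy and cyano only and does not extend to the five-membered aromatic ring. Set against the 4-carboxyphenyl arm, the 3-(1H-tetrazol-5-yl)phenyl arm gives an 11-fold higher number from compound 2 to compound 4 (1.04 log units; beyond the scatter), so compound 4 stands apart from both carboxy compounds as well as from the nitrile.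

Nothing measured alongside these compounds explains why the tetrazole stands apart. Going by these compounds, how a 2-methyltetrazol-5-yl group or a primary carboxamide on the same aromatic carbon would read remains open, and with it whether the shift follows the tetrazole ring as a whole or only its ring hydrogen.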